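Chain change on the aromatic nitrogen of compound 2

The source may report more compounds than this note shows. Statements on the series, on what has been measured and on what is new or still open speak of the compounds shown alone.

Of the compounds shown here, two on the shared core have been read so far in an ADME assay on Huh-7 cells (Homo sapiens) for cytotoxicity, with a stated time of 72 h; on this read-out lower numbers stand for higher toxicity in this test and higher numbers for lower toxicity in this test. Compound 1 `CC(C)CCn1nc(CC(C)C)c(O)c(C2=NS(=O)(=O)c3cc(NS(C)(=O)=O)ccc3N2)c1=O` gives > 1000 nM, which is a limit of the assay and not a number. Compound 2 `CCC(C)CCn1nc(-c2cccs2)c(O)c(C2=NS(=O)(=O)c3cc(NS(C)(=O)=O)ccc3N2)c1=O` gives > 1000 nM, which is also a limit and not a number. Going by the values given here, the series so far sits at the limit of > 1000 nM in this assay, at which 2 of the 2 values shown sit, so the readings give no order among the compounds.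

Compound 3 `CCCC(C)n1nc(-c2cccs2)c(O)c(C2=NS(=O)(=O)c3cc(NS(C)(=O)=O)ccc3N2)c1=O` keeps the rest of compound 2 but carries 1-methylbutyl in place of 3-methylpentyl on an aromatic nitrogen. Among the compounds with values here, no measured step between compounds is available in this assay, and two limits fix no size of change. No step beyond the usual scatter is expected in either direction, and another limit reading is the likeliest outcome. The expected change is a step that the limit leaves unreadable from compound 2 to compound 3. This expectation rests on the limit reading of compound 2 at > 1000 nM. For compound 3 the estimated value is 3000 nM, with an expected range of 1000 nM to 10000 nM.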

Compound 3, half-maximal cytotoxic concentration: > 33000 nM
Compound 3: only a limit was reported; the forecaster's own chance of this, stated with the estimate: 85%; at least 11-fold (1.04 log units) between middle value and limit.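

In this assay compound 3 gives > 33000 nM, which is a limit and not a number. Going by these compounds alone, compound 2 also stands at a limit, > 1000 nM, so no step from compound 2 to compound 3 can be read. The compounds shown leave open whether 1-methylbutyl in place of 3-methylpentyl changes this read-out at all.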